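The source may report more compounds than this note shows. Statements on the series, on what has been measured and on what is new or still open speak of the compounds shown alone.

Compound 3, with the structure `O=C(Nc1ccc(S(=O)(=O)Nc2ncccn2)cc1)c1ccc(Cl)cc1Cl`, stands at the edge of what the numbers show. In a functional assay on HEK293 cells for agonist activity at probable G-protein coupled receptor 27 (Homo sapiens), read by a luciferase reporter and beta-arrestin recruitment, with a stated time of 10 min (a lower number here means that less compound is needed, a higher number that more compound is needed for the effect), compound 3 gives > 100000 nM, which is a limit of the assay and not a number. The same is true of compound 1, the structure `O=C(Nc1ccc(S(=O)(=O)NCc2ccccc2)cc1)c1ccc(Cl)cc1Cl`, whose value in this assay is > 100000 nM, also a limit. Only compound 2, with the structure `O=C(Nc1ccc(S(=O)(=O)Nc2cccc(Cl)c2)cc1)c1ccc(Cl)cc1Cl`, gives a number in this assay, namely 575 nM. Thus, with the limit of > 100000 nM in this assay, at which 2 of the 3 values shown sit, two of the three values sit at the limit. The step of an at least 170-fold lower number from compound 1 to compound 2 (2.24 log units; beyond the scatter) and the step of an at least 170-fold higher number from compound 2 to compound 3 (2.24 log units; beyond the scatter) are both large, whereas the step that the two limits leave unreadable from compound 1 to compound 3 cannot be read between two limits.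

Compound 4, the structure `O=C(Nc1ccc(S(=O)(=O)Nc2ccccc2Cl)cc1)c1ccc(Cl)cc1Cl`, carries the change (2-chlorophenyl in place of pyrimidin-2-yl on a sulfonamide nitrogen), that is, a 2-chlorophenyl in place of pyrimidin-2-yl on a sulfonamide nitrogen. Compound 2 bears a 3-chlorophenyl at the same place and gives a number, so the change is expected to move away from the limit. The estimate therefore implies a step of an at least 66-fold lower number from compound 3 to compound 4 (1.82 log units; beyond the scatter) in this assay. For compound 4 the value in this assay is estimated at 1500 nM, with a range from 300 nM to 20000 nM.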

Compound 4, half-maximal effective concentration: 1260 nM
Beside the measured number, compound 4's estimate is 1.2-fold (0.08 log units) above it; the measured number falls inside the stated range.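

Compound 4 shows that a readable value in this assay is not tied to the 3-chlorophenyl of compound 2, since 2-chlorophenyl on the sulfonamide nitrogen also gives a number, and the step between these two chlorophenyl groups is a 2.2-fold higher number from compound 2 to compound 4 (0.34 log units; beyond the scatter). Set against the other two groups, 2-chlorophenyl gives an at least 79-fold lower number from compound 3 to compound 4 (1.89 log units; beyond the scatter) and an at least 79-fold lower number from compound 1 to compound 4 (1.89 log units; beyond the scatter), so among the four compounds both chlorophenyl groups give numbers, while pyrimidin-2-yl and benzyl do not. These last two steps are minimum sizes only, because compound 1 and compound 3 each carry a limit and not a number: the limit of > 100000 nM in this assay, at which 2 of the 4 values shown sit.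

The compounds shown leave open whether the chlorine itself is needed, which a plain phenyl, or a methyl or methoxy in place of the chlorine, would address. They also leave open whether a chlorobenzyl on the sulfonamide nitrogen would give a number where the benzyl of compound 1 gives only a limit.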